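Swapping the aryl group on the carbonyl carbon

The compounds below may be only part of what the source reports. "The series", "measured", "known", "first", "only" and "open" are said of these compounds alone.

Of the compounds shown here, two built on a shared core have been tested in a functional assay on HCT-116 cells (Homo sapiens) for cytotoxicity, read by MTT assay, with a stated time of 48 h; on this read-out higher numbers stand for weaker inhibition and lower numbers for stronger inhibition. Compound 1 `O=C(/C=C/c1ccc2c(c1)B(O)OC2)c1ccco1` gives 24100 nM. Compound 2 `Nc1ccc(C(=O)/C=C/c2ccc3c(c2)B(O)OC3)cc1` carries 4-aminophenyl on the carbonyl carbon where compound 1 carries furan-2-yl. In this assay compound 2 gives 26100 nM. Going by the values given here, the only measured step, a 1.1-fold higher number from compound 1 to compound 2 (0.03 log units; within the scatter), shows that exchanging one aryl group for another at this place did not move the read-out beyond the scatter, so compound 2 stands level with compound 1 rather than apart from it. Compound 3 `O=C(/C=C/c1ccc2c(c1)B(O)OC2)c1ccccc1F` differs from compound 2 by 2-fluorophenyl in place of 4-aminophenyl on a carbonyl carbon. Among the compounds with values here, this is again an exchange of one aryl group for another on the same carbonyl carbon, and the single comparable step was within the scatter. Compound 3 is therefore expected to land close to compound 2, with a 1.0-fold lower number from compound 2 to compound 3 (0.02 log units; within the scatter) predicted to stay within the scatter. The estimate for compound 3 in this assay is 25000 nM, with a range from 8000 nM to 75000 nM.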

Compound 3, half-maximal inhibitory concentration: 4200 nM
Estimate against measurement, compound 3: 6.0-fold (0.77 log units) above; measured number outside the range, below it.
By their numbers in this assay, from the lowest: compound 3; then compounds 1 and 2 (each within the scatter of the next).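

The aryl group on the carbonyl carbon is not interchangeable after all in this assay: putting 2-fluorophenyl there gives a clear change (a 6.2-fold lower number from compound 2 to compound 3 (0.79 log units; beyond the scatter)) and a similar one against the furan (a 5.7-fold lower number from compound 1 to compound 3 (0.76 log units; beyond the scatter)). The earlier pair, 4-aminophenyl and furan-2-yl, stood level and suggested that this place tolerates any aryl group without effect, but compound 3 shows that the read-out does respond to what sits here. Going by these compounds alone, nothing measured so far accounts for why 2-fluorophenyl stands apart from the other two groups.

The compounds shown leave open whether the fluorine itself or its place in 2-fluorophenyl carries this step, and plain phenyl, 4-fluorophenyl or 2-chlorophenyl on the same carbonyl carbon would separate these readings. As far as these compounds go, whether the lower number holds in other cell lines also remains open.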